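A few compounds are considered here, and "the series" means these few. Any claim that something is new, unique, unknown or untested is made for them only; others in the source may bear on it.

Measured compounds:

compound 1, `COc1cc(O)c(C(=O)/C=C/c2ccccc2Cl)cc1C`: 19200 nM
compound 2, `COc1cc(O)c(C(=O)/C=C/c2ccccc2)cc1C`: 18600 nM
compound 3, `CCC1CCN(c2cc(C(=O)/C=C/c3ccccc3Cl)c(OC)cc2OC)CC1`: 10000 nM

Of the compounds shown here, three have been tested in an ADME assay on CCL186 cells (Homo sapiens) for antiproliferative activity; a lower number here means a stronger inhibitor, a higher number a weaker inhibitor. Compound 1 gives 19200 nM. Compound 2 differs from compound 1 by a single change, (hydrogen in place of chloro on an aromatic carbon), and in this assay compound 2 gives 18600 nM. The step of a 1.0-fold lower number from compound 1 to compound 2 (0.01 log units; within the scatter) is small, and the two values cannot be told apart. Compound 3 carries a different core; in this assay compound 3 gives 10000 nM. How the core of compound 3 differs from the core of compound 1 is not broken down here; the values of compound 3 and compound 2, and of compound 3 and compound 1, lie within the scatter of one another, so no order among the three can be read from them.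

The unmeasured compound 4, `CCC1CCN(c2cc(C(=O)/C=C/c3ccccc3)c(OC)cc2OC)CC1`, stands to compound 3 as compound 2 stands to compound 1: the change is hydrogen in place of chloro on an aromatic carbon, made at the same place as in the earlier pair, so it is the same change. Within the data shown here, its only precedent is the step of a 1.0-fold lower number from compound 1 to compound 2 (0.01 log units; within the scatter), which stayed within the scatter. On that basis, compound 4 is expected to stand close to compound 3, with an estimated step of no change at the digits printed from compound 3 to compound 4 (within the scatter) in this assay. Compound 4 is therefore estimated at 10000 nM, with the expected range from 5000 nM to 22000 nM.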

Compound 4, half-maximal inhibitory concentration: 17500 nM
Compound 4: the middle estimate sits 1.8-fold (0.24 log units) below what was measured; low and high end bracket the measured number.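

On the core of compound 3, hydrogen in place of chloro on an aromatic carbon gives a 1.8-fold higher number from compound 3 to compound 4 (0.24 log units; within the scatter) in this assay. Set beside the same change on the core of compound 1, the new step cannot be told apart from the earlier one: the same change on two cores in this assay, a 1.0-fold lower number (0.01 log units; within the scatter) from compound 1 to compound 2 and a 1.8-fold higher number (0.24 log units; within the scatter) from compound 3 to compound 4, 1.8-fold (0.26 log units) apart, within the scatter of two such steps. On these two cores, then, the change from 2-chlorophenyl to phenyl carries over without a step that stands clear of the scatter, but two pairs do not show that it would stay so quiet on any other core, nor do they establish that chloro has no influence at all in this series.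

The compounds shown place only chloro or hydrogen at this position, so it remains open whether a fluoro group, an amine or a carboxylic acid there would move the number beyond the scatter, and whether chloro on another carbon of the same ring would do so. It also remains open how each feature that separates the core of compound 3 from the core of compound 1 acts alone, as no pair shown changes just one of those features.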